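Oxamic Acids on a Cyanophenyl Core: From Methyl to Isopropoxy

The source may hold more compounds than are shown below. What is called first, only, known or untested is meant among the compounds shown, and "the series" means these compounds.

Measured compounds:
compound 1, `CCN(CC)c1cccc(NC(=O)C(=O)O)c1C#N`, 99.2%
compound 2, `Cc1cccc(NC(=O)C(=O)O)c1C#N`, 32.3%

Among the measured compounds shown here, in a functional assay on the whole organism for inhibition, with Rattus norvegicus as the target, at a dose of 1 mg/kg by the oral route (on this read-out lower numbers stand for less inhibition and higher numbers for more inhibition at the one dose given (going by the name of the read-out)), compound 2 stands lowest of the two numbers measured so far; its nearest neighbour is compound 1, which lies far above it. For the measured compounds named here, the one step measured on this core, a number 66.9 percentage points lower from compound 1 to compound 2 (beyond the scatter), shows that a methyl group at this position goes with a much smaller read-out than a diethylamino group.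

Compound 3, `CC(C)Oc1cccc(NC(=O)C(=O)O)c1C#N`, has not yet been measured. It differs from compound 2 in one place: isopropoxy in place of methyl on an aromatic carbon. Going by the values given here, no measured pair carries an isopropoxy group, so the only step that bears on this change is the one from compound 1 to compound 2, and it bears on it indirectly, since it tells only how methyl compares with diethylamino at the same aromatic carbon. That step was large, and it shows that the number with methyl is lower than the number with diethylamino at this position. Among the compounds with values here, on that basis compound 3 is expected to move upward from compound 2, with the step of a number 32.7 percentage points higher from compound 2 to compound 3 (beyond the scatter) as the estimate, though the size is uncertain because only the step of a number 66.9 percentage points lower from compound 1 to compound 2 (beyond the scatter) is available as a guide. For compound 3 the estimated value is 65%, within a range from 30% to 95%.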

Compound 3, a percentage reported as inhibition, in the whole organism at one dose (the size of the read-out at that dose, not a potency): 75.1%
Compound 3: middle estimate off by 10.1 percentage points, on the low side; the measured number falls inside the stated range.
By their numbers in this assay, from the lowest: compound 2; then compound 3; then compound 1.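

In this assay, the isopropoxy group shows that the read-out at this aromatic carbon, ortho to a cyano group, does not depend on a nitrogen-linked substituent: an oxygen-linked group also lifts it far above the level seen with methyl (a number 42.8 percentage points higher from compound 2 to compound 3 (beyond the scatter)). Diethylamino nevertheless remains ahead of isopropoxy, though this gap is smaller than the one separating isopropoxy from methyl (a number 24.1 percentage points lower from compound 1 to compound 3 (beyond the scatter)), so the three compounds now form an order, rising from methyl through isopropoxy to diethylamino, with each step beyond the scatter. Nothing available explains why the three groups fall in this order.

The compounds shown leave open where a smaller ether such as methoxy, a longer chain such as n-butoxy, or a cyclic amine such as pyrrolidine would fall in this order at the same aromatic carbon. They also leave open whether a smaller amine such as dimethylamino would keep the read-out close to that of compound 1, or whether it would fall back toward that of compound 3.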